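The source may report more compounds than this note shows. Statements on the series, on what has been measured and on what is new or still open speak of the compounds shown alone.

Measured in a functional assay on DU-145 cells (Homo sapiens) for inhibition, read by trypan blue exclusion, with a stated time of 96 h; a higher number here means a weaker inhibitor of growth, a lower number a stronger inhibitor of growth:
Compound 1 `CN(C)c1ccc(/C=C(\C(=O)c2ccc(Cl)cc2)S(=O)(=O)c2ccc(Br)cc2)cc1`: > 100000 nM (a limit)
Compound 2 `CN(C)c1ccc(/C=C(/SCc2ccc(Cl)cc2)C(=O)c2ccc(Cl)cc2)cc1`: > 100000 nM (a limit)
Compound 3 `CN(C)c1ccc(/C=C(/SCc2ccc(Cl)c(Cl)c2)C(=O)c2ccc(Cl)cc2)cc1`: 50000 nM

For the measured compounds named here, compound 3 gives the only real number in this small series, 50000 nM. The rest of the series is described by the limit of > 100000 nM in this assay, at which 2 of the 3 values shown sit.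

Compound 4 `CN(C)c1ccc(/C=C(/SCc2ccc(Cl)cc2Cl)C(=O)c2ccc(Cl)cc2)cc1` is an isomer of compound 3: 2,4-dichlorophenyl in place of 3,4-dichlorophenyl on a saturated chain carbon bound to a sulfur. In words, 2,4-dichlorophenyl stands in place of 3,4-dichlorophenyl on a saturated chain carbon bound to a sulfur.

Going by the values given here, two measured steps bear on this change, and both are only floors: an at least 2.0-fold lower number from compound 2 to compound 3 (0.30 log units; that floor lies within the scatter) and an at least 2.0-fold lower number from compound 1 to compound 3 (0.30 log units; that floor lies within the scatter). Among the compounds with values here, neither shows a size beyond the scatter, and no measured pair tests this shift of a chlorine. On these data alone, no step beyond the scatter is therefore expected in this assay, and either direction remains open. The expected change is no change at the digits printed from compound 3 to compound 4 (within the scatter). Compound 4 is estimated at 50000 nM, with an expected range of 20000 nM to 100000 nM.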

Compound 4, concentration for 50% growth inhibition: 50000 nM
The estimate for compound 4 equals the measured number at the digits printed, and the stated range covers the measured number.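

In this assay, 2,4-dichlorophenyl in place of 3,4-dichlorophenyl on a saturated chain carbon bound to a sulfur gives no change at the digits printed from compound 3 to compound 4 (within the scatter), and this is the only pair shown that tests where this chlorine stands. The added chloro in the 2,4-dichlorobenzyl series gives an at least 2.0-fold lower number from compound 2 to compound 4 (0.30 log units; that floor lies within the scatter), while the (2,4-dichlorobenzyl)sulfanyl group in place of the (4-bromophenyl)sulfonyl group gives an at least 2.0-fold lower number from compound 1 to compound 4 (0.30 log units; that floor lies within the scatter), so neither step shows a size beyond the scatter. Both of these comparisons start from a limit, not a number: the limit of > 100000 nM in this assay, at which 2 of the 4 values shown sit.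

The compounds shown leave open whether a methoxy group or an amine on this phenyl group would give a number clearly different from those of compound 3 and compound 4. They also leave open what a longer chain between the sulfur and the phenyl group would do.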